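Lengthening the carbamate chain on a selenocyanate aryl carbamate

The source may report more compounds than this note shows. Statements on the series, on what has been measured and on what is new or still open speak of the compounds shown alone.

Three aryl carbamates carrying selenium have been tested in an ADME assay on 184B5 cells (Homo sapiens) for cytotoxicity, read by MTT assay, with a stated time of 72 h; a lower number here means a stronger inhibitor of growth, a higher number a weaker inhibitor of growth. Compound 1 `CCCOC(=O)Nc1ccc([Se]C#N)cc1` gives 9100 nM, and compound 2 `CC(C)COC(=O)Nc1ccc([Se]C#N)cc1` gives 21600 nM, while compound 3 `CCCCCCOC(=O)Nc1ccc([Se][Se]c2ccc(NC(=O)OCCCCCC)cc2)cc1`, whose two selenium atoms join two identical parts, gives 9800 nM. Among these three numbers compound 2 stands highest, and the change from compound 1 to compound 2, a methyl in place of hydrogen on a saturated chain carbon bound to two saturated chain carbons, gave a 2.4-fold higher number from compound 1 to compound 2 (0.38 log units; beyond the scatter).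

Compound 4 `CCCCCCOC(=O)Nc1ccc([Se]C#N)cc1` has not yet been measured. Relative to compound 2 the change is pentyl in place of isopropyl on a saturated chain carbon bound to an oxygen next to a carbonyl group, so the branch point disappears and the chain grows to pentyl. Among the compounds with values here, only one measured step bears on this: the branching step from compound 1 to compound 2, which raised the number modestly. Undoing that branching points in the opposite direction, and compound 3, which carries the same hexyl carbamate, sits close to compound 1. The expectation for this assay is therefore a drop of about a 2.2-fold lower number from compound 2 to compound 4 (0.33 log units; beyond the scatter), bringing compound 4 back near the other two. Compound 4 is estimated at 10000 nM, within a range from 5000 nM to 20000 nM.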

Compound 4, concentration for total growth inhibition: 20000 nM
For compound 4 the middle estimate is 2.0-fold (0.30 log units) below the measured one; measured number inside the range.
By their numbers in this assay, from the lowest: compounds 1 and 3 (each within the scatter of the next); then compounds 4 and 2 (each within the scatter of the next).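

In this assay the isobutyl and hexyl carbamates cannot be told apart, with a 1.1-fold lower number from compound 2 to compound 4 (0.03 log units; within the scatter) as the step, so a branch point is not needed for a number at this level. Lengthening the straight chain at this place goes the same way as branching it, with a 2.2-fold higher number from compound 1 to compound 4 (0.34 log units; beyond the scatter) as the step from the propyl carbamate, and this holds only for these three selenocyanates. Nothing shown gives a measured reason why a branched chain and a longer straight chain land together.

The compounds shown leave open whether the number keeps rising with a longer chain such as octyl, or stays low with a shorter one such as ethyl. They also leave open what a chain ending in an amine or a carboxylic acid would do at this place, on a saturated chain carbon bound to an oxygen next to a carbonyl group, and whether a branch on the hexyl chain would add anything to the effect of its length.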